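This account rests on a few compounds, and the source may have more. Where it says the series, first, only, none or still open, it means among the compounds named here.

In an ADME assay on HEK-293T cells (Homo sapiens) for inhibition, read by CCK-8 assay, with a stated time of 48 h, tested at 20 uM (on this read-out higher numbers stand for more inhibition of growth at the one concentration tested and lower numbers for less inhibition of growth), compound 1 `COc1ccc(Cc2nnc(NC(=O)/C(C#N)=C/c3ccccc3OS(=O)(=O)c3ccc(Cl)cc3)s2)cc1` gives 34% and compound 2 `COc1ccc(S(=O)(=O)Oc2ccccc2/C=C(\C#N)C(=O)Nc2nnc(Cc3cccc4ccccc34)s2)cc1` gives 29%, two values within the scatter of each other. Compound 3 `N#C/C(=C\c1ccccc1OS(=O)(=O)c1ccc(Cl)cc1)C(=O)Nc1nnc(Cc2cccc3ccccc23)s1` has chloro in place of methoxy on an aromatic carbon of compound 2, para to a large group: chloro in place of methoxy on an aromatic carbon. Going by the values given here, no measured pair shows this change on its own. Compound 1 already carries a 4-chlorophenyl group and gives 34%, which offers no sign of a large shift. The estimated step of a number 2 percentage points higher from compound 2 to compound 3 (within the scatter) is expected to stay within the scatter, in neither direction. Compound 3 is estimated at 31%, with an expected range from 18% to 45%.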

Compound 3, percent growth inhibition at one concentration: 16%
Compound 3: the middle estimate sits 15 percentage points above what was measured; the whole stated range lies above it.
By their numbers in this assay, from the lowest: compound 3; then compounds 2 and 1 (each within the scatter of the next).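

In this assay, chloro in place of methoxy on an aromatic carbon, para to a large group, gives a number 13 percentage points lower from compound 2 to compound 3 (beyond the scatter) and so shows that this position can register a single change beyond the scatter. Naphthalen-1-yl in place of 4-methoxyphenyl on a saturated chain carbon bound to an aromatic carbon gives a number 18 percentage points lower from compound 1 to compound 3 (beyond the scatter) in the same direction. No measurement on hand accounts for either step. The compounds shown leave open how an amine or a carboxylic acid on that aromatic carbon would read, and whether the chloro step would hold with 4-methoxyphenyl on the chain.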